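Adding a methoxy group to the aryl ketone of compound 1

The source may report more compounds than this note shows. Statements on the series, on what has been measured and on what is new or still open speak of the compounds shown alone.

Compound 1 `COc1ccc(C(=O)/C=C/c2cc(-c3cc(OC)c(OC)c(OC)c3)n3nc(-c4ccccc4)cc3n2)cc1` was tested in a functional assay on A549 cells (Homo sapiens) for antiproliferative activity, read by MTT assay, with a stated time of 24 h (a higher number here means a weaker inhibitor, a lower number a stronger inhibitor), and gave 14600 nM, which places it second highest among the three numbers recorded so far. Compound 2 `COc1ccc(C(=O)/C=C/c2cc(-c3ccc(OC)c(OC)c3)n3nc(-c4ccccc4)cc3n2)cc1` gives 11900 nM, and compound 3 `COc1cc(-c2cc(C(=O)/C=C/c3ccc(C)cc3)nc3cc(-c4ccccc4)nn23)cc(OC)c1OC` gives 20000 nM. Both steps from compound 1 are small: a 1.2-fold lower number from compound 1 to compound 2 (0.09 log units; within the scatter), and a 1.4-fold higher number from compound 1 to compound 3 (0.14 log units; within the scatter). Compound 4 `COc1ccc(C(=O)/C=C/c2cc(-c3cc(OC)c(OC)c(OC)c3)n3nc(-c4ccccc4)cc3n2)cc1OC` has not yet been measured. It differs from compound 1 by methoxy in place of hydrogen on an aromatic carbon. Among the measured compounds shown here, no measured step repeats this change on this ring; the nearest in kind is the removal of a methoxy group on the other aromatic ring, which gave a step within the scatter from compound 1 to compound 2, and the change on the aryl ketone side from compound 1 to compound 3 also stayed within the scatter. Compound 4 is therefore expected to show no step beyond the scatter in this assay, a 1.0-fold lower number from compound 1 to compound 4 (0.02 log units; within the scatter). Compound 4 is estimated at 14000 nM, with a range from 7000 nM to 28000 nM.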

Compound 4, half-maximal inhibitory concentration: 17800 nM
Compound 4: the middle estimate sits 1.3-fold (0.10 log units) below what was measured, within the range that was stated.
By their numbers in this assay, from the lowest: compounds 2, 1, 4 and 3 (each within the scatter of the next).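

Among the compounds shown, only this step changes the aryl ketone ring while leaving the rest of compound 1 intact. In this assay, going from (4-methoxyphenyl)carbonyl to (3,4-dimethoxyphenyl)carbonyl gives a 1.2-fold higher number from compound 1 to compound 4 (0.09 log units; within the scatter), so a methoxy group placed here, ortho to a methoxy group and meta to a large group, produces no step beyond the scatter. Nothing available bears on the reason for this result.

With methoxy as the only group shown at this position, the result cannot say whether the position would tolerate other groups. An amine, a carboxylic acid or a longer chain such as butoxy in the same place could show whether the number stays within the scatter of compound 1 or moves beyond it.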